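A few compounds are considered here, and "the series" means these few. Any claim that something is new, unique, unknown or untested is made for them only; others in the source may bear on it.

Working notes on the series. Among the compounds with values here, compound 2 `Nc1cc(N)c2nc(-c3ccccc3)c(NCc3ccc(Cl)c(Cl)c3)nc2c1` gives 9550 nM in a functional assay on SK-MEL-2 cells (Homo sapiens) for inhibition, read by sulforhodamine B assay, with a stated time of 48 h (a lower number here means that less compound is tolerated, a higher number that more compound is tolerated), and stands lowest of the two numbers measured so far. Compound 1 `Nc1cc(N)c2nc(-c3ccccc3)c(Oc3ccc(Cl)c(Cl)c3)nc2c1` gives 89100 nM in this assay, a higher number than compound 2 and one beyond the scatter. Compound 3 `CCOC(=O)[C@H](CCC(=O)O)NC(=O)c1ccc(Oc2nc3cc(N)cc(N)c3nc2-c2ccccc2)cc1` gives only a limit in this assay, < 100000 nM (the limit of < 100000 nM in this assay, at which 1 of the 3 values shown sits). Compound 4 `COc1ccc(CNc2nc3cc(N)cc(N)c3nc2-c2ccccc2)cc1` is not yet measured; it differs from compound 2 by 4-methoxyphenyl in place of 3,4-dichlorophenyl on a saturated chain carbon bound to a nitrogen on an aromatic ring. Within the data shown here, no measured pair carries this change, so its size is unknown; a modest rise in the number, or none beyond the scatter, is expected. Compound 4 is estimated at 20000 nM in this assay, with a range of 6000 nM to 60000 nM. The expected step is then a 2.1-fold higher number from compound 2 to compound 4 (0.32 log units; beyond the scatter).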

Compound 4, concentration lethal to 50% of the cells: 57500 nM
The estimate for compound 4 lay 2.9-fold (0.46 log units) below the measured number; the range from low to high includes it.
By their numbers in this assay, from the lowest: compound 2; then compounds 4 and 1 (each within the scatter of the next).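

At this place, on a saturated chain carbon bound to a nitrogen on an aromatic ring, the group carried by the chain now has a measured effect: in this assay, 4-methoxyphenyl in place of 3,4-dichlorophenyl gives a 6.0-fold higher number from compound 2 to compound 4 (0.78 log units; beyond the scatter). So the number responds to this change, whereas the earlier compounds offered no single-place comparison. Nothing measured here bears on why the step has this size.

Still open, as far as these compounds go, is whether removing the chlorines or adding the methoxy group sets the step. From the compounds shown here alone, how an amine, a carboxylic acid or a longer chain would read at this place is also open.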